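The source may hold more compounds than are shown below. What is called first, only, known or untested is meant among the compounds shown, and "the series" means these compounds.

In a functional assay on OVCAR-3 cells (Homo sapiens) for antiproliferative activity (a lower number here means a stronger inhibitor of growth, a higher number a weaker inhibitor of growth), compound 1 (`Oc1cc(-c2ccc3ccccc3c2)nc2ncccc12`) gives 8320 nM, compound 2 (`Cc1ccnc2nc(-c3ccc4ccccc4c3)cc(O)c12`) gives 1290 nM and compound 3 (`Cc1ccc2c(O)cc(-c3ccc4ccccc4c3)nc2n1`) gives 3630 nM, the second highest of the three numbers. Compound 4 (`Cc1cc(C)c2c(O)cc(-c3ccc4ccccc4c3)nc2n1`) differs from compound 3 in one place: methyl in place of hydrogen on an aromatic carbon. Two measured steps make the same kind of replacement, and both are modest and lead to a lower number. The closer guide is a 6.4-fold lower number from compound 1 to compound 2 (0.81 log units; beyond the scatter), since that methyl also stands opposite the ring nitrogen. The other is a 2.3-fold lower number from compound 1 to compound 3 (0.36 log units; beyond the scatter). Among the measured compounds shown here, no measured compound shows whether two methyl groups add up, so a somewhat smaller step toward a lower number is expected in this assay. The expected step is a 4.5-fold lower number from compound 3 to compound 4 (0.66 log units; beyond the scatter). For compound 4 the estimate is 800 nM, with a range of 280 nM to 2400 nM.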

Compound 4, concentration for 50% growth inhibition: 20000 nM
Beside the measured number, compound 4's estimate is 25-fold (1.40 log units) below it, and the stated range ends below it.
By their numbers in this assay, from the lowest: compound 2; then compound 3; then compound 1; then compound 4.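

In this assay, methyl in place of hydrogen on an aromatic carbon gives a higher number once a second methyl is present, with a 5.5-fold higher number from compound 3 to compound 4 (0.74 log units; beyond the scatter) and a 16-fold higher number from compound 2 to compound 4 (1.19 log units; beyond the scatter). The replacement opposite the ring nitrogen therefore has no fixed direction, and its outcome depends on the core that carries it: the same change on two cores in this assay, a 6.4-fold lower number (0.81 log units; beyond the scatter) from compound 1 to compound 2 and a 5.5-fold higher number (0.74 log units; beyond the scatter) from compound 3 to compound 4, 36-fold (1.55 log units) apart, beyond the scatter of two such steps The other methyl also reverses direction when the first is present: the same change on two cores in this assay, a 2.3-fold lower number (0.36 log units; beyond the scatter) from compound 1 to compound 3 and a 16-fold higher number (1.19 log units; beyond the scatter) from compound 2 to compound 4, 36-fold (1.55 log units) apart, beyond the scatter of two such steps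

The compounds shown leave open whether only methyl reverses the direction on these cores. An ethyl group, a methoxy group or an amine opposite the ring nitrogen on the core of compound 3 would test that.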